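The source may report more compounds than this note shows. Statements on the series, on what has been measured and on what is new or still open speak of the compounds shown alone.

Compound 2 `CCc1cccc2c(OC)c(-c3occ(C)c3C(=O)NC)ccc12` is measured in a functional assay on SK-BR-3 cells (Homo sapiens) for cytotoxicity, read by MTT assay, with a stated time of 72 h (a higher number here means that more compound is needed for the effect, a lower number that less compound is needed), and there it reaches only the limit > 10 ug/mL, not a number. Its parent, compound 1 `CCc1cccc2c(OC)c(-c3occ(C)c3C(=O)OC)ccc12`, gives 1.2 ug/mL in this assay. Among the compounds with values here, the one measured step, an at least 8.3-fold higher number from compound 1 to compound 2 (0.92 log units; beyond the scatter), is at least modest; its size is bounded because of the limit of > 10 ug/mL in this assay, at which 1 of the 2 values shown sits. Compound 3 `CCc1cccc2c(OC)c(-c3occ(C)c3C(=O)On3nnc4ccccc43)ccc12` changes the same carbonyl carbon once more: a group of 10 heavy atoms (6 carbon, 3 nitrogen, 1 oxygen; one five-membered aromatic ring with 3 hetero atoms, one six-membered aromatic ring of carbon only) in place of a group of 2 heavy atoms (1 carbon, 1 nitrogen; no ring), on a carbonyl carbon. Compound 2 thus loses the methylamino group that the step from compound 1 brought in, and compound 3 carries, like compound 1, an oxygen-linked group on the carbonyl. Within the data shown here, since the only measured step points in the direction of a higher number when methylamino enters, its removal is expected to give a lower number in this assay, though the size is uncertain. Compound 3 is therefore estimated at 2 ug/mL, in the range 0.5 ug/mL to 10 ug/mL. The expected step is an at least 5.0-fold lower number from compound 2 to compound 3 (0.69 log units; beyond the scatter).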

Compound 3, concentration for half-maximal effect: > 10 ug/mL
Compound 3 was reported as a limit (the forecaster's own chance of this, stated with the estimate: 25%); middle value at least 5.0-fold (0.69 log units) from the limit.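

In this assay, replacing the methoxy group of compound 1 with the larger oxygen-linked group gives an at least 8.3-fold higher number from compound 1 to compound 3 (0.92 log units; beyond the scatter). An oxygen link on the carbonyl carbon is therefore not enough to retain a readable value, and among the three compounds only the methoxy group of compound 1 gives one. The step between compound 2 and compound 3 cannot be read, so the methylamino group and the larger group cannot be ranked, and what can be said about this position is bounded by a single limit: the limit of > 10 ug/mL in this assay, at which 2 of the 3 values shown sit.

On these data alone, how far compound 2 and compound 3 lie beyond that limit remains open. As far as these compounds go, it is also open whether ethoxy, a slightly longer oxygen-linked group, or a carboxylic acid at the same carbonyl carbon would give a value close to that of compound 1.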